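This account rests on a few compounds, and the source may have more. Where it says the series, first, only, none or still open, it means among the compounds named here.

The measured compounds:
- compound 1, `CN(C)CCn1cnnc1-c1cc(Oc2ccc(NC(=O)N/N=C/c3ccc(F)cc3F)cc2F)ccn1`, gives 5030 nM in an ADME assay on WI-38 cells (Homo sapiens) for cytotoxicity, read by MTT assay, with a stated time of 72 h; a lower number here means a stronger inhibitor, a higher number a weaker inhibitor
- compound 2, `CN(C)CCn1cnnc1-c1cc(Oc2ccc(NC(=O)N/N=C/c3cccc(Cl)c3Cl)cc2F)ccn1`, gives 6130 nM in this assay
- compound 3, `CN(C)CCn1cnnc1-c1cc(Oc2ccc(NC(=O)N/N=C/c3c(O)ccc4ccccc34)cc2F)ccn1`, gives 3250 nM in this assay

Compound 3 carries the lowest of the three numbers, yet its gaps to the other two are within the scatter: a 1.5-fold lower number from compound 1 to compound 3 (0.19 log units; within the scatter) and a 1.9-fold lower number from compound 2 to compound 3 (0.28 log units; within the scatter). The three compounds share one core and differ only in the group on a carbon with a double bond to nitrogen. Compound 4, `CN(C)CCn1cnnc1-c1cc(Oc2ccc(NC(=O)N/N=C/c3cccc(Br)c3)cc2F)ccn1`, changes that same group once more: 3-bromophenyl in place of 2-hydroxynaphthalen-1-yl on a carbon with a double bond to nitrogen. Among the compounds with values here, the steps that bear on this are the changes already seen at that place, namely a 1.2-fold higher number from compound 1 to compound 2 (0.09 log units; within the scatter) together with the two steps to compound 3 just given, all within the scatter. Three different groups at this place have given numbers within the scatter of one another, so no step beyond the scatter is expected in this assay for compound 4. The estimate for compound 4 is 5000 nM, with a range from 2500 nM to 10000 nM, which means an expected step of a 1.5-fold higher number from compound 3 to compound 4 (0.19 log units; within the scatter).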

Compound 4, half-maximal inhibitory concentration: 4230 nM
Estimate against measurement, compound 4: 1.2-fold (0.07 log units) above, within the range that was stated.
By their numbers in this assay, from the lowest: compounds 3, 4, 1 and 2 (each within the scatter of the next).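

Swapping the two-ring 2-hydroxynaphthalen-1-yl, with its hydrogen-bond donor and acceptor, for the one-ring 3-bromophenyl, with neither, gives a 1.3-fold higher number from compound 3 to compound 4 (0.11 log units; within the scatter) in this assay and so stays within the scatter. The new group also stays within the scatter of the two halogen-bearing groups seen earlier, with a 1.4-fold lower number from compound 2 to compound 4 (0.16 log units; within the scatter) and a 1.2-fold lower number from compound 1 to compound 4 (0.08 log units; within the scatter), so all four groups at this place now give numbers that cannot be told apart in this measurement. Nothing measured here explains why these groups give such similar numbers.

All four groups are aromatic rings, so an amine, a carboxylic acid or a longer alkyl chain on this carbon remains untested among the compounds shown. On these data alone, whether any group at this place can produce a step beyond the scatter also stays open.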